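The source may report more compounds than this note shows. Statements on the series, on what has been measured and on what is new or still open speak of the compounds shown alone.

Compound 1 `C=CC(=O)Nc1nc(-c2ccccc2OC)cs1`: > 30000 nM
Compound 2 `C=CC(=O)N(Cc1cc(C)no1)c1nc(-c2ccccc2)cs1`: > 30000 nM

In a functional assay on HT-29 cells (Homo sapiens) for antiproliferative activity, read by MTT assay, with a stated time of 72 h (on this read-out higher numbers stand for weaker inhibition and lower numbers for stronger inhibition), compound 1 gives > 30000 nM, which is a limit of the assay and not a number. Compound 2 gives > 30000 nM, also a limit. Compound 2 therefore stands at the limit of > 30000 nM in this assay, at which 2 of the 2 values shown sit, with no number to mark its true place.

Compound 3 `C=CC(=O)N(Cc1cc(C)no1)c1nc(-c2ccccc2OC)cs1` is the next to be read in this assay. It differs from compound 2 by methoxy in place of hydrogen on an aromatic carbon, with methoxy in place of hydrogen on an aromatic carbon, ortho to a large group. The change turns phenyl into 2-methoxyphenyl, a group that compound 1 also carries. Going by the values given here, no measured step shows what this change does, so only a small shift toward stronger inhibition is expected, with none beyond the scatter as the likeliest outcome. The expected step of an at least 1.2-fold lower number from compound 2 to compound 3 (0.07 log units; that floor lies within the scatter) is an estimate and nothing firmer. For compound 3 the estimated value is 25000 nM, with an expected range of 6000 nM to 60000 nM.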

Compound 3, half-maximal inhibitory concentration: > 30000 nM
Compound 3: a limit, no number (the forecaster's own chance of this, stated with the estimate: 60%); middle value at least 1.2-fold (0.07 log units) away from the limit.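

In this assay compound 3 sits at a limit of the assay, as compound 1 and compound 2 do, so neither step to compound 3 can be read. From the compounds shown here alone, what methoxy or (3-methyl-1,2-oxazol-5-yl)methyl does to inhibition in these compounds stays open.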